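This account rests on a few compounds, and the source may have more. Where it says the series, first, only, none or still open, it means among the compounds named here.

Measured compounds and their values in a functional assay for activation of Alpha-1D adrenergic receptor (Homo sapiens), read by calcium flux; a higher number here means that more compound is needed for the effect, a lower number that less compound is needed:
- compound 1, `c1cncc(-c2ccccc2OCC2=NCCN2)c1`: 158 nM
- compound 2, `c1ccc(-c2ccncc2)c(OCC2=NCCN2)c1`: compound 2 gives only a limit of the assay, < 100000 nM
- compound 3, `c1c[nH]c(-c2ccccc2OCC2=NCCN2)c1`: 6.31 nM

Among the numbers shown, compound 1 stands highest; the nearest is compound 3, which lies a 25-fold lower number from compound 1 to compound 3 (1.40 log units; beyond the scatter) away. For compound 2 the assay reports a limit rather than a number, so the steps a step that the limit leaves unreadable from compound 1 to compound 2 and a step that the limit leaves unreadable from compound 2 to compound 3 cannot be sized; this is the limit described by the limit of < 100000 nM in this assay, at which 1 of the 3 values shown sits.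

Compound 4, `c1ccc(-c2ccsc2)c(OCC2=NCCN2)c1`, has not yet been measured. It differs from compound 1 in that (thiophen-3-yl in place of pyridin-3-yl on an aromatic carbon). Among the measured compounds shown here, the one measured step that bears on this change is the one from compound 1 to compound 3, a 25-fold lower number from compound 1 to compound 3 (1.40 log units; beyond the scatter), in which a five-membered aromatic ring with one hetero atom likewise replaced pyridin-3-yl on the same aromatic carbon. The new ring in compound 4 carries sulfur rather than the ring nitrogen of compound 3, so a gain of similar direction but smaller size is expected. Compound 4 is therefore estimated to give 32 nM in this assay, within 8 nM to 130 nM, which would mean an expected step of a 4.9-fold lower number from compound 1 to compound 4 (0.69 log units; beyond the scatter).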

Compound 4, half-maximal effective concentration: 12.6 nM
Estimate against measurement, compound 4: 2.5-fold (0.40 log units) above; low and high end bracket the measured number.
By their numbers in this assay, from the lowest: compounds 3 and 4 (each within the scatter of the next); then compound 1.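

In this assay, a second five-membered aromatic ring also gives a large gain at this aromatic carbon: a 13-fold lower number from compound 1 to compound 4 (1.10 log units; beyond the scatter). The gain over pyridin-3-yl is thus not confined to 1H-pyrrol-2-yl and persists with thiophen-3-yl, which carries sulfur and no ring nitrogen, while the two five-membered rings cannot be told apart here: a 2.0-fold higher number from compound 3 to compound 4 (0.30 log units; within the scatter). Steps involving compound 2 cannot be read, as compound 2 gives only a limit of the assay: the limit of < 100000 nM in this assay, at which 1 of the 4 values shown sits.

As far as these compounds go, it remains open whether the gain follows the five-membered ring itself or the loss of the pyridine nitrogen, and a plain phenyl ring at this carbon would separate the two. From the compounds shown here alone, how a furan-3-yl or thiophen-2-yl ring would stand against thiophen-3-yl also remains open.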